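Closing the Butylamino Chain into a Ring

The source may hold more compounds than are shown below. What is called first, only, known or untested is meant among the compounds shown, and "the series" means these compounds.

Measured so far in a functional assay on CHO-K1 cells for antagonist activity at transient receptor potential cation channel subfamily V member 1 (Homo sapiens), read by FLIPR; on this read-out lower numbers stand for stronger inhibition and higher numbers for weaker inhibition:
compound 1 `CCCCNc1nc(C(F)(F)F)ccc1CNC(=O)C(C)c1ccc(NS(C)(=O)=O)c(F)c1`, 9.1 nM
compound 2 `CC(C(=O)NCc1ccc(C(F)(F)F)nc1Nc1ccc(F)cc1)c1ccc(NS(C)(=O)=O)c(F)c1`, 39.2 nM
compound 3 `CC(C(=O)NCc1ccc(C(F)(F)F)nc1N(C)c1ccccc1)c1ccc(NS(C)(=O)=O)c(F)c1`, 0.9 nM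

Compound 1 stands second highest of these three numbers. Its nearest neighbour is compound 2, reached by a 4.3-fold higher number from compound 1 to compound 2 (0.63 log units; beyond the scatter); its furthest is compound 3, reached by a 10-fold lower number from compound 1 to compound 3 (1.00 log units; beyond the scatter). Compound 4 `CC(C(=O)NCc1ccc(C(F)(F)F)nc1N1CCCC1)c1ccc(NS(C)(=O)=O)c(F)c1` differs from compound 1 in one place: pyrrolidin-1-yl in place of butylamino on an aromatic carbon. Within the data shown here, no measured pair shows exactly this change. Among the measured compounds shown here, the steps that bear on it are those in which the butylamino or the (4-fluorophenyl)amino group gives way to methyl(phenyl)amino: a 10-fold lower number from compound 1 to compound 3 (1.00 log units; beyond the scatter) and a 44-fold lower number from compound 2 to compound 3 (1.64 log units; beyond the scatter), both lowering the number clearly beyond the scatter. Pyrrolidin-1-yl keeps the same count of heavy atoms as butylamino, so a step of that size is not assured, but the direction is expected to be the same. Compound 4 is therefore expected to give about 5 nM in this assay, within 1.5 nM to 20 nM. The expected step is a 1.8-fold lower number from compound 1 to compound 4 (0.26 log units; within the scatter).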

Compound 4, inhibition constant: 0.6 nM
For compound 4 the middle estimate is 8.3-fold (0.92 log units) above the measured one; measured number below the stated range.
By their numbers in this assay, from the lowest: compounds 4 and 3 (each within the scatter of the next); then compound 1; then compound 2.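

In this assay, at this position next to the ring nitrogen, tying the butylamino chain into a ring gives a 15-fold lower number from compound 1 to compound 4 (1.18 log units; beyond the scatter), although the count of 5 heavy atoms stays the same and the hydrogen-bond donors go from 1 to 0. An aromatic ring on the nitrogen is not needed to reach this level, as pyrrolidin-1-yl and methyl(phenyl)amino cannot be told apart, with a 1.5-fold lower number from compound 3 to compound 4 (0.18 log units; within the scatter), while the step from the (4-fluorophenyl)amino compound is a 65-fold lower number from compound 2 to compound 4 (1.82 log units; beyond the scatter). No measurement shown here explains these differences.

The compounds shown do not separate the effect of the ring from that of losing the nitrogen's hydrogen, a question that an open methyl(butyl)amino group would address. From the compounds shown here alone, how the ring size bears on the result also stays open, with azetidin-1-yl and piperidin-1-yl as the neighbouring cases.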